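A few compounds are considered here, and "the series" means these few. Any claim that something is new, unique, unknown or untested is made for them only; others in the source may bear on it.

Compounds measured in an assay on COS-7 cells for inhibition of patatin-like phospholipase domain-containing protein 2 (Mus musculus); a higher number here means a weaker inhibitor, a lower number a stronger inhibitor:
- compound 1, `CCOC(=O)c1cccc(-c2ccc(N(C)C)cc2)c1`, 40000 nM
- compound 2, `CCOC(=O)c1cccc(-c2ccc([N+](=O)[O-])cc2)c1`, 95000 nM
- compound 3, `CCOC(=O)c1cccc(-c2ccc(C)cc2)c1`, 140000 nM

Compound 3 gives the highest number of the three; the gap to compound 2 is within the scatter, while the step of a 3.5-fold higher number from compound 1 to compound 3 (0.54 log units; beyond the scatter) lies beyond it. Compound 4, `CCOC(=O)c1cccc(-c2ccc(CN3CCCC3)cc2)c1`, differs from compound 3 by pyrrolidin-1-yl in place of hydrogen on a saturated chain carbon bound to an aromatic carbon. For the measured compounds named here, no measured step alters this position, so none bears on it directly; the steps of a 2.4-fold higher number from compound 1 to compound 2 (0.38 log units; beyond the scatter) and a 3.5-fold higher number from compound 1 to compound 3 (0.54 log units; beyond the scatter) only show that compound 1, which carries a nitrogen-bearing group, gave the lowest number, modestly. On that basis, a modest lowering is expected for compound 4, as a 3.1-fold lower number from compound 3 to compound 4 (0.49 log units; beyond the scatter), giving an estimate of 45000 nM with a range from 12000 nM to 160000 nM.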

Compound 4, half-maximal inhibitory concentration: > 200000 nM
Compound 4: no number, only a limit (the forecaster's own chance of this, stated with the estimate: 15%); middle value at least 4.4-fold (0.64 log units) away from the limit.
By their numbers in this assay, from the lowest: compound 1; then compounds 2 and 3 (each within the scatter of the next). At a limit, above all of these: compound 4.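

In this assay compound 4 is recorded only as a limit of the assay, not as a number: the limit of > 200000 nM in this assay, at which 1 of the 4 values shown sits. Pyrrolidin-1-yl on a saturated chain carbon bound to an aromatic carbon brought no lowering, with an at least 1.4-fold higher number from compound 3 to compound 4 (0.15 log units; that floor lies within the scatter), so the nitrogen of compound 1 did not carry its low number over to this group. Exchanging the whole group gives an at least 2.1-fold higher number from compound 2 to compound 4 (0.32 log units; beyond the scatter) and an at least 5.0-fold higher number from compound 1 to compound 4 (0.69 log units; beyond the scatter). Open remains whether a dimethylamino group or a morpholine ring at this same place would behave like pyrrolidin-1-yl.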